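Swapping the Furan on a Shared Core

The source may report more compounds than this note shows. Statements on the series, on what has been measured and on what is new or still open speak of the compounds shown alone.

Measured so far:
Compound 1 `Cc1cccc(Nc2nccc(-c3cc(C)oc3C)n2)c1` gives 28500 nM in a functional assay for inhibition, with Homo sapiens as the target; a higher number here means a weaker inhibitor, a lower number a stronger inhibitor.
Compound 2 `Cc1cc(C)cc(Nc2nccc(-c3cc(C)oc3C)n2)c1` gives 4100 nM in this assay.
Compound 3 `CC(=O)N(C)c1ccc(Nc2nccc(-c3cccnc3)n2)cc1` gives 900 nM in this assay.

Compound 2 stands second highest of these three numbers: compound 3 lies lower by a gap beyond the scatter, and compound 1 lies higher, that one measured step being a 7.0-fold lower number from compound 1 to compound 2 (0.84 log units; beyond the scatter). Compound 4 `Cc1cc(C)cc(Nc2nccc(-c3ccco3)n2)c1` differs from compound 2 in one place: furan-2-yl in place of 2,5-dimethylfuran-3-yl on an aromatic carbon. Within the data shown here, no measured step touches this ring; the step between compound 1 and compound 2 concerns a methyl on another ring, and compound 3 differs from compound 2 in two places at once. The direction is therefore open, and only a small step is expected: a 1.2-fold higher number from compound 2 to compound 4 (0.09 log units; within the scatter). For compound 4 the estimate in this assay is 5000 nM, with a range from 1500 nM to 20000 nM.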

Compound 4, half-maximal inhibitory concentration: 700 nM
Beside the measured number, compound 4's estimate is 7.1-fold (0.85 log units) above it; the measured number lies below the stated range.
By their numbers in this assay, from the lowest: compounds 4 and 3 (each within the scatter of the next); then compound 2; then compound 1.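

Among these compounds, this is the first measured change to the furan on the shared core, and in this assay going to furan-2-yl gives a 5.9-fold lower number from compound 2 to compound 4 (0.77 log units; beyond the scatter) and so shows that the number responds to the group at this position. The smaller, unmethylated furan is the better of the two here. Nothing available explains this difference.

Going by these compounds, compound 4 loses both methyl groups and changes the furan's point of attachment at once, so the source of the lower number stays open. Also open, on these data alone, is how a thiophene-2-yl or a furan bearing a carboxylic acid would fare here.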